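The source may report more compounds than this note shows. Statements on the series, on what has been measured and on what is new or still open speak of the compounds shown alone.

Measured in an ADME assay on cells for inhibition of Intestinal-type alkaline phosphatase (Homo sapiens), read by luminescence, with stated times of 7 min and 20 min; on this read-out higher numbers stand for weaker inhibition and lower numbers for stronger inhibition:
compound 1 `CCCNc1nn2c(=O)cc(C(F)(F)F)nc2s1` gives 310 nM
compound 2 `CN(N)c1nn2c(=O)cc(C(F)(F)F)nc2s1` gives 2220 nM
compound 3 `CCOc1ccccc1-c1nn2c(=O)cc(C(F)(F)F)nc2s1` gives > 100000 nM

On these data alone, compound 3 is the only one of the three that carries a six-membered carbon ring on the shared core, and its value is a limit of this assay rather than a number, so where it truly stands is unknown; at that limit (the limit of > 100000 nM in this assay, at which 1 of the 3 values shown sits). Compound 1 and compound 2 both sit well inside the measured range.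

Compound 4 `O=c1cc(C(F)(F)F)nc2sc(-c3ccccc3F)nn12` keeps the ring of compound 3 but changes one group on it: fluoro in place of ethoxy on an aromatic carbon. Among the measured compounds shown here, the only measured step, a 7.2-fold higher number from compound 1 to compound 2 (0.85 log units; beyond the scatter), concerns a different place on the core, where an amino group rather than a ring is attached, so it says little about swapping one ring substituent for another. What remains is that compound 3 itself gave no number in this assay. Compound 4 is therefore expected to stay close to that, with the step of a number no higher from compound 3 to compound 4 (the limit leaves the size open) carrying much uncertainty in both directions. The estimate for compound 4 in this assay is 100000 nM, within a wide range from 10000 nM to 1000000 nM.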

Compound 4, half-maximal inhibitory concentration: > 100000 nM
Compound 4: only a limit was reported; the forecaster's own chance of this, stated with the estimate: 60%; the middle value sits exactly at the limit.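

In this assay compound 4 gives > 100000 nM, which is a limit and not a number, just as the value of compound 3 is, so the step between these two compounds cannot be read. Putting 2-fluorophenyl in the place of the nitrogen-linked groups gives an at least 45-fold higher number from compound 2 to compound 4 (1.65 log units; beyond the scatter) and an at least 320-fold higher number from compound 1 to compound 4 (2.50 log units; beyond the scatter), both beyond the usual scatter, so the fall in inhibition seen with compound 3 does not depend on ethoxy alone. Among the compounds shown, the two with a six-membered carbon ring on the shared core, compound 3 and compound 4, now stand at the limit, while the two with a nitrogen-linked group, compound 1 and compound 2, give measured values: the limit of > 100000 nM in this assay, at which 2 of the 4 values shown sit.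

On these data alone, the limits hide how compound 3 and compound 4 truly compare, so it stays open whether the group on the ring matters at all. As far as these compounds go, it also stays open whether a ring carrying an amine or a carboxylic acid would bring the read-out back into the measurable range, and how a longer chain than propylamino would fare on the shared core.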